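Swapping Benzoyl for Phenylsulfonyl on Compound 3

This account rests on a few compounds, and the source may have more. Where it says the series, first, only, none or still open, it means among the compounds named here.

Measured so far, each value a limit:
Compound 1 `CCC(CC)O[C@@H]1C=C(C(=O)O)C[C@H](NCc2ccc(C(C)C)cc2)[C@H]1NC(C)=O`: > 200000 nM
Compound 2 `CCC(CC)O[C@@H]1C=C(C(=O)O)C[C@H](NCc2ccc(C(C)(C)C)cc2)[C@H]1NC(C)=O`: > 200000 nM
Compound 3 `CCC(CC)O[C@@H]1C=C(C(=O)O)C[C@H](NCc2ccc(C(=O)c3ccccc3)cc2)[C@H]1NC(C)=O`: > 200000 nM

These results come from an ADME assay on cells (Fibroblast, Gallus gallus) for cytotoxicity, read by CCK-8 assay, with a stated time of 48 h; on this read-out higher numbers stand for lower toxicity in this test and lower numbers for higher toxicity in this test. Compound 3 gives > 200000 nM, which is a limit and not a number. Compounds 1 and 2 also stand at a limit, so no order among the three can be read: the limit of > 200000 nM in this assay, at which 3 of the 3 values shown sit.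

The next structure is compound 4 `CCC(CC)O[C@@H]1C=C(C(=O)O)C[C@H](NCc2ccc(S(=O)(=O)c3ccccc3)cc2)[C@H]1NC(C)=O`, which carries phenylsulfonyl in place of benzoyl on an aromatic carbon, para to a large group: phenylsulfonyl in place of benzoyl on an aromatic carbon. Among the measured compounds shown here, no measured step makes this exact exchange. The closest are the two steps that bring benzoyl in, a step that the two limits leave unreadable from compound 1 to compound 3 and a step that the two limits leave unreadable from compound 2 to compound 3, and neither has a readable size. They give no sign of a change in this assay, so no step beyond the usual scatter is expected, in either direction. The expected step is a step that the limit leaves unreadable from compound 3 to compound 4. For compound 4 the estimate is 250000 nM, with an expected range from 130000 nM to 500000 nM. Another limit may well be reported instead of a number.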

Compound 4, half-maximal cytotoxic concentration: > 200000 nM
Compound 4 was reported as a limit (the forecaster's own chance of this, stated with the estimate: 85%); the middle value does not contradict the limit.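

Among the compounds shown here, compound 4 also stands at a limit, so no step from compound 1, compound 2 or compound 3 to compound 4 can be read in this assay: the limit of > 200000 nM in this assay, at which 4 of the 4 values shown sit. The compounds shown leave open at what concentration any of them harms these cells, and whether the four differ at all.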